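The source may report more compounds than this note shows. Statements on the series, on what has been measured and on what is new or still open speak of the compounds shown alone.

Measured so far:
Compound 1 `CC(C)Oc1cc(NC(=N)c2ccccn2)ccc1-c1ccc(-c2cncnc2)o1`: > 20000 nM
Compound 2 `CC(C)Oc1cc(NC(=N)c2ccccn2)ccc1-c1ccc(-c2ccncc2)o1`: 22000 nM

Within the data shown here, in an ADME assay on J774.A1 cells (Mus musculus) for cytotoxicity, read by MTT assay, with a stated time of 72 h (a lower number here means a stronger inhibitor, a higher number a weaker inhibitor), compound 2 gives 22000 nM, the only true number available. Compound 1 gives > 20000 nM, which is a limit of the assay and not a number. Compound 2 therefore cannot yet be ranked against another measured value.

Compound 3 `COc1ccccc1-c1ccc(-c2ccc(NC(=N)c3ccccn3)cc2OC(C)C)o1` keeps the core of compound 2 and changes one group: 2-methoxyphenyl in place of pyridin-4-yl on an aromatic carbon. In short, 2-methoxyphenyl sits in place of pyridin-4-yl on an aromatic carbon.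

Among the measured compounds shown here, only one measured step bears on this change, as it also swaps the group at this place: a step that the limit leaves unreadable from compound 1 to compound 2. Its size cannot be read, so it offers no guide to the size or direction of the next step. The starting point for compound 3 is thus simply compound 2 at 22000 nM, and no step beyond the usual scatter is expected in this assay.

The expected change is a 1.2-fold lower number from compound 2 to compound 3 (0.09 log units; within the scatter). For compound 3, the estimated value is 18000 nM, with an expected range from 6000 nM to 40000 nM.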

Compound 3, half-maximal inhibitory concentration: 5300 nM
Compound 3: middle estimate off by 3.4-fold (0.53 log units), on the high side, and the stated range ends above it.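

Among these compounds, changing the group next to the ring oxygen does move the number in this assay: 2-methoxyphenyl in place of pyridin-4-yl gives a 4.2-fold lower number from compound 2 to compound 3 (0.62 log units; beyond the scatter) and so gives the first readable step at this place. Set against pyrimidin-5-yl, the same group gives an at least 3.7-fold lower number from compound 1 to compound 3 (0.57 log units; beyond the scatter) and points the same way, while the step between the two earlier compounds cannot be read. Compound 3 is the only one of the three with a ring of carbon only at this place, and it is the strongest inhibitor of these cells among them, which shows that this position is not indifferent to the group it carries.

The change swaps the ring and adds a methoxy group at once, so the compounds shown leave open which of the two goes with the lower number, a question that a plain phenyl ring or a 2-hydroxyphenyl group at the same place could help to settle. The size of the difference from compound 1 also stays open, and its reading is a limit of the assay and not a number: the limit of > 20000 nM in this assay, at which 1 of the 3 values shown sits.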